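Swapping one amine for another on a weak cytotoxic compound

The source may report more compounds than this note shows. Statements on the series, on what has been measured and on what is new or still open speak of the compounds shown alone.

Measured in a functional assay on A549 cells (Homo sapiens) for cytotoxicity, read by MTT assay; a higher number here means a weaker inhibitor, a lower number a stronger inhibitor:
compound 1 `N#Cc1c(F)c(Cl)c2nc(N)nc(N)c2c1F` gives 30.8 ug/mL
compound 2 `CC(C)(C)Nc1c(C#N)c(F)c2c(N)nc(N)nc2c1Cl` gives 313 ug/mL

Of these two numbers, compound 2 has the higher, at 313 ug/mL, which makes it the weaker inhibitor of the pair.

Compound 3 `CCN(CC)c1c(C#N)c(F)c2c(N)nc(N)nc2c1Cl` differs from compound 2 in a single place: diethylamino in place of (tert-butyl)amino on an aromatic carbon. In words, diethylamino stands in place of (tert-butyl)amino on an aromatic carbon.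

Within the data shown here, only one measured step bears on this change: a 10-fold higher number from compound 1 to compound 2 (1.01 log units; beyond the scatter), where (tert-butyl)amino came in place of fluoro on an aromatic carbon. That step shows that a change at an aromatic carbon can move the number well beyond the scatter. It replaced fluoro, however, whereas here one amino group replaces another built from the same atoms. Among the measured compounds shown here, no measured step compares two such groups, so the direction remains open, and a much smaller step is expected in this assay, probably none beyond the scatter.

The estimated change is a 1.4-fold lower number from compound 2 to compound 3 (0.13 log units; within the scatter). For compound 3 the expected value is 230 ug/mL, with an estimated range from 70 ug/mL to 650 ug/mL.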

Compound 3, half-maximal inhibitory concentration: 7.1 ug/mL
Estimate against measurement, compound 3: 32-fold (1.51 log units) above; measured number below the stated range.
By their numbers in this assay, from the lowest: compound 3; then compound 1; then compound 2.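

In this assay the two amines at this aromatic carbon are far from interchangeable: the change gives a 44-fold lower number from compound 2 to compound 3 (1.64 log units; beyond the scatter) even though (tert-butyl)amino and diethylamino each have 5 heavy atoms, 4 carbon and 1 nitrogen. The earlier step suggested that an amine here might only weaken the compound, but the comparison with fluoro now shows a 4.3-fold lower number from compound 1 to compound 3 (0.64 log units; beyond the scatter) and so runs the opposite way, which makes compound 3 the strongest inhibitor of the three and shows that the direction depends on which amine is present. The counted difference between the two amines is 1 hydrogen-bond donor in (tert-butyl)amino against 0 in diethylamino, and their atoms are joined differently, but no measurement here explains the size of the step.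

Ethylamino would separate the presence of a hydrogen-bond donor from the size of the group, while dimethylamino or dipropylamino would show how the number follows chain length. Morpholine or pyrrolidine at the same carbon would show whether the low number survives when the two chains on the nitrogen are tied into a ring.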